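The compounds below may be only part of what the source reports. "The series", "measured", "known", "first", "only" and "open" are said of these compounds alone.

Of the compounds shown here, three built on one shared core have so far been measured in a functional assay on MCF7 cells (Homo sapiens) for cytotoxicity, read by MTT assay, with a stated time of 72 h; a higher number here means a weaker inhibitor, a lower number a stronger inhibitor. Compound 1 `O=C1c2c[n+]([O-])c3ccccc3c2C(=O)c2c1c1ccccc1n2Cc1cn([C@H]2O[C@H](CO)[C@@H](O)[C@H]2O)nn1` gives 1490 nM. Compound 2 `O=C1c2c[n+]([O-])c3ccccc3c2C(=O)c2c1c1ccccc1n2CCN1CCCC1` gives 320 nM. Compound 3 `CCCN1CCN(CCCCn2c3c(c4ccccc42)C(=O)c2c[n+]([O-])c4ccccc4c2C3=O)CC1` gives 1280 nM, the second highest of the three numbers: it lies within the scatter of compound 1, while a 4.0-fold higher number from compound 2 to compound 3 (0.60 log units; beyond the scatter) separates it from compound 2. Among the measured compounds shown here, compound 4 `O=C1c2c[n+]([O-])c3ccccc3c2C(=O)c2c1c1ccccc1n2Cc1cn(C[C@H](O)CO)nn1` has not been measured; it differs from compound 3 in one place: 1-(2,3-dihydroxypropyl)-1H-1,2,3-triazol-4-yl in place of 3-(4-propylpiperazin-1-yl)propyl on a saturated chain carbon bound to an aromatic nitrogen The single measured step alters a group two bonds along the chain from an aromatic nitrogen and so bears only loosely on this change. Compound 1 also carries a 1,2,3-triazol-4-yl group on this carbon and gives 1490 nM, close to compound 3; on that ground a small step is expected, a 1.2-fold higher number from compound 3 to compound 4 (0.07 log units; within the scatter). Compound 4 is estimated at 1500 nM, with a range from 600 nM to 4000 nM.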

Compound 4, half-maximal inhibitory concentration: > 1000 nM
Compound 4 ended at the assay's limit (the forecaster's own chance of this, stated with the estimate: 5%); the middle value lies beyond the limit too.
By their numbers in this assay, from the lowest: compound 2; then compounds 3 and 1 (each within the scatter of the next).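

In this assay compound 4 gives > 1000 nM, which is a limit of the assay and not a number. Even so, putting 1-(2,3-dihydroxypropyl)-1H-1,2,3-triazol-4-yl in place of (pyrrolidin-1-yl)methyl on this saturated chain carbon gives an at least 3.1-fold higher number from compound 2 to compound 4 (0.49 log units; beyond the scatter), so this triazole does not match the pyrrolidine chain of compound 2. The steps to compound 4 from compound 3 and from compound 1 cannot be read, as the reading stops at the limit: the limit of > 1000 nM in this assay, at which 1 of the 4 values shown sits.

Still open, going by these compounds, is whether another amine on this chain, such as morpholine or dimethylamine, would keep the number of compound 2. On these data alone, the true value of compound 4 also remains unknown.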